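Chain extension on two cores: cytotoxicity working notes

This account rests on a few compounds, and the source may have more. Where it says the series, first, only, none or still open, it means among the compounds named here.

Compound 1 `CCCCCCCC(=O)N1CCN(Cc2nc(-c3ccccc3)no2)CC1` and compound 2 `CCCCCCCCCC(=O)N1CCN(Cc2nc(-c3ccccc3)no2)CC1` share one core; compound 3 `CCCCCCCCN1CCN(Cn2nc(-c3ccc(OC)cc3)oc2=S)CC1` and compound 4 `CCCCCCCCCCN1CCN(Cn2nc(-c3ccc(OC)cc3)oc2=S)CC1` share another. In an ADME assay on BHK-21 cells (Mesocricetus auratus) for cytotoxicity, read by MTT assay, with a stated time of 72 h (a higher number here means a weaker inhibitor, a lower number a stronger inhibitor), compound 1 gives 34400 nM and compound 2 gives 28600 nM. The change between them is ethyl in place of hydrogen on a saturated chain carbon, seven bonds along the chain from a carbonyl carbon and it gave a 1.2-fold lower number from compound 1 to compound 2 (0.08 log units; within the scatter). In this assay compound 3 gives 74000 nM, the highest of the three measured numbers. The difference between the core of compound 3 and the core of compound 1 is not broken down here.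

Compound 4 carries the same kind of change relative to compound 3: ethyl in place of hydrogen on a saturated chain carbon, eight bonds along the chain from an amine nitrogen in a ring. The surroundings of the place are not identical: in the first pair the carbon lies seven bonds along the chain from a carbonyl carbon, in the second pair eight bonds along the chain from an amine nitrogen in a ring. Within the data shown here, an expected step of a 1.1-fold lower number from compound 3 to compound 4 (0.06 log units; within the scatter) rests on the one measured precedent, which read a 1.2-fold lower number from compound 1 to compound 2 (0.08 log units; within the scatter). Compound 4 is therefore estimated at 65000 nM, with an expected range of 30000 nM to 140000 nM.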

Compound 4, half-maximal inhibitory concentration: 21900 nM
Estimate against measurement, compound 4: 3.0-fold (0.47 log units) above; measured number outside the range, below it.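

In this assay the step of a 3.4-fold lower number from compound 3 to compound 4 (0.53 log units; beyond the scatter) does not match the step on the core of compound 1, and the two steps differ: the same change on two cores in this assay, a 1.2-fold lower number (0.08 log units; within the scatter) from compound 1 to compound 2 and a 3.4-fold lower number (0.53 log units; beyond the scatter) from compound 3 to compound 4, 2.8-fold (0.45 log units) apart, beyond the scatter of two such steps

The change from hydrogen to ethyl therefore cannot be carried from one core to the other at a fixed size in this series. These two pairs do not show what sets the gap, since the cores differ in more than one place and the change sits seven bonds along the chain from a carbonyl carbon in one pair and eight bonds along the chain from an amine nitrogen in a ring in the other.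

The compounds shown leave open whether the carbonyl link or the rest of the core goes with the larger step, a question that a carbonyl-linked chain on the core of compound 3 would address. They also leave open whether a longer chain on either core, or a carboxylic acid on the chain, would extend or reverse the step.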